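Notes on compound 4 in the acylurea-thiazole series

A few compounds are considered here, and "the series" means these few. Any claim that something is new, unique, unknown or untested is made for them only; others in the source may bear on it.

Compound 1 `CN(C(=O)NC(=O)c1ccc(Cl)cc1Cl)c1nc(C(F)(F)F)c(C(=O)N/N=C/c2ccc(C(F)(F)F)cc2)s1` gives 12.4 ug/mL in a functional assay on HepG2 cells (Homo sapiens) for inhibition, read by MTT assay, with a stated time of 72 h; on this read-out lower numbers stand for stronger inhibition and higher numbers for weaker inhibition. Among the three compounds measured it stands second highest: compound 3 `CN(C(=O)NC(=O)c1cccc(C(F)(F)F)c1)c1nc(C(F)(F)F)c(C(=O)N/N=C/c2ccc(C(F)(F)F)cc2)s1` sits nearest with 7.71 ug/mL, and compound 2 `CN(C(=O)NC(=O)c1c(F)cccc1F)c1nc(C(F)(F)F)c(C(=O)N/N=C/c2ccc(C(F)(F)F)cc2)s1` furthest with 49.6 ug/mL. All measured steps change the group on the carbonyl carbon: a 4.0-fold higher number from compound 1 to compound 2 (0.60 log units; beyond the scatter), a 1.6-fold lower number from compound 1 to compound 3 (0.21 log units; within the scatter) and a 6.4-fold lower number from compound 2 to compound 3 (0.81 log units; beyond the scatter).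

Compound 4 `CN(C(=O)NC(=O)c1ccc(Cl)cc1Cl)c1nc(C(F)(F)F)c(C(=O)N/N=C/c2cccc(C(F)(F)F)c2)s1` differs from compound 1 at another place: 3-(trifluoromethyl)phenyl in place of 4-(trifluoromethyl)phenyl on a carbon with a double bond to nitrogen. Going by the values given here, no measured step touches the carbon with a double bond to nitrogen, so none of the three steps bears directly on this change. Among the compounds with values here, what is known is only that exchanging aryl groups on the carbonyl carbon moved this assay by modest amounts at most, and here the same atoms are merely joined differently. No step beyond the scatter is expected in either direction. Compound 4 is estimated at 12 ug/mL, within 5 ug/mL to 30 ug/mL, meaning an expected step of a 1.0-fold lower number from compound 1 to compound 4 (0.01 log units; within the scatter).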

Compound 4, half-maximal inhibitory concentration: 11.2 ug/mL
For compound 4 the middle estimate is 1.1-fold (0.03 log units) above the measured one; low and high end bracket the measured number.
By their numbers in this assay, from the lowest: compounds 3, 4 and 1 (each within the scatter of the next); then compound 2.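

Moving the trifluoromethyl group gives the first reading at the carbon with a double bond to nitrogen: in this assay there is a 1.1-fold lower number from compound 1 to compound 4 (0.04 log units; within the scatter), so with 2,4-dichlorophenyl on the carbonyl carbon, 3-(trifluoromethyl)phenyl and 4-(trifluoromethyl)phenyl cannot be told apart here. The clearest step in the series remains the exchange on the carbonyl carbon, with a 6.4-fold lower number from compound 2 to compound 3 (0.81 log units; beyond the scatter), while this one pair shows no such separation at the new position. No evidence to hand bears on the reason for this result.

The compounds shown leave open whether this match holds with 2,6-difluorophenyl or 3-(trifluoromethyl)phenyl on the carbonyl carbon. They also leave open how this assay responds when an amine, a carboxylic acid or a longer alkyl chain stands in place of the trifluoromethyl group.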